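The source may hold more compounds than are shown below. What is called first, only, known or untested is meant among the compounds shown, and "the series" means these compounds.

Of the compounds shown here, three sharing one core have been measured in a functional assay on NCI-H522 cells (Homo sapiens) for cytotoxicity, read by sulforhodamine B assay, with a stated time of 48 h, tested at 0.01 uM; on this read-out higher numbers stand for a weaker effect at the one concentration tested and lower numbers for a stronger effect. Compound 1 `COc1ccc(-c2cc(/C=C/C(=O)c3ccc(N)cc3)[nH]n2)cc1` gives 84%. Compound 2 `COc1cc(-c2cc(/C=C/C(=O)c3ccc(N)cc3)[nH]n2)cc(OC)c1OC` gives 92%. Compound 3 `COc1ccc(C(=O)/C=C/c2cc(-c3cc(OC)c(OC)c(OC)c3)n[nH]2)cc1OC` gives 83%. On these numbers compound 2 stands highest of the three, yet its distance to compound 1 and its distance to compound 3 both fall within the usual scatter, so no order among the three can be read from them.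

Compound 4 `COc1cc(-c2cc(/C=C/C(=O)c3ccc(F)c(F)c3)[nH]n2)cc(OC)c1OC` has not yet been measured. It differs from compound 2 in one place: 3,4-difluorophenyl in place of 4-aminophenyl on a carbonyl carbon. For the measured compounds named here, one measured step bears on this, the one that also replaces the 4-aminophenyl on the carbonyl carbon: a number 9 percentage points lower from compound 2 to compound 3 (within the scatter). That exchange for 3,4-dimethoxyphenyl left the read-out within the scatter. Going by the values given here, the exchange for 3,4-difluorophenyl has no direct precedent among the measured compounds, so that single step is the only guide, and on it no step beyond the scatter is expected in this assay in either direction.

Compound 4 is therefore estimated at 88%, with a range from 76% to 100%. This estimate means an expected step of a number 4 percentage points lower from compound 2 to compound 4 (within the scatter).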

Compound 4, a percentage reported as activity, at one concentration (the size of the read-out at that concentration, not a potency): 96%
Compound 4: the middle estimate sits 8 percentage points below what was measured, and the stated range covers the measured number.
By their numbers in this assay, from the lowest: compounds 3, 1, 2 and 4 (each within the scatter of the next, the first and the last beyond it).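

In this assay, a second exchange on the carbonyl carbon, 3,4-difluorophenyl in place of 4-aminophenyl, gives a number 4 percentage points higher from compound 2 to compound 4 (within the scatter) and so again leaves the read-out within the scatter. For the compounds shown here, the new compound also yields the first step that lies beyond the scatter, though only modestly: swapping 3,4-dimethoxyphenyl for 3,4-difluorophenyl gives a number 13 percentage points higher from compound 3 to compound 4 (beyond the scatter) and so shows a weaker effect at the one concentration tested, which means the group on the carbonyl carbon can shift this read-out even though compound 2 cannot be told apart from either of the other two. Nothing measured here explains why these two groups differ.

It remains open how a plain phenyl, a 4-hydroxyphenyl or a group carrying a carboxylic acid would read on the same carbonyl carbon, and whether any of them would give a stronger effect than the groups shown. A single low concentration also leaves open whether this modest step would persist at higher concentrations.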